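Vinylcarbonyl in place of propylsulfonyl

The source may report more compounds than this note shows. Statements on the series, on what has been measured and on what is new or still open speak of the compounds shown alone.

In a functional assay on HeLa cells (Homo sapiens) for cytotoxicity, read by MTT assay, with a stated time of 72 h (a lower number here means a stronger inhibitor, a higher number a weaker inhibitor), compound 1 `CCCS(=O)(=O)Nc1ccc(-c2cn3c(C(=O)OCC)csc3n2)cc1` gives > 20000 nM as its result, which is a limit and not a number. In this assay compound 2 `CCOC(=O)c1csc2nc(-c3cccc(NC(=O)CCl)c3)cn12` gives 20000 nM as a measured value. Compound 3 `C=CC(=O)Nc1ccc(-c2cn3c(C(=O)OCC)csc3n2)cc1` carries vinylcarbonyl in place of propylsulfonyl on a nitrogen on an aromatic ring. Among the compounds with values here, no measured step covers this change, so only a small shift toward stronger inhibition is expected, and the expected step of an at least 1.3-fold lower number from compound 1 to compound 3 (0.12 log units; that floor lies within the scatter) may stay within the scatter. For compound 3 the estimated value is 15000 nM with an expected range from 5000 nM to 25000 nM in this measurement.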

Compound 3, half-maximal inhibitory concentration: > 20000 nM
Compound 3 was reported as a limit; the forecaster's own chance of this, stated with the estimate: 45%; at least 1.3-fold (0.12 log units) between middle value and limit.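

Compound 1 and compound 3 are both reported only as limits in this assay, so no step can be read between them. The compounds shown leave open how vinylcarbonyl and propylsulfonyl on this nitrogen compare, with both results resting at one limit: the limit of > 20000 nM in this assay, at which 2 of the 3 values shown sit.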